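Chloro to Cyano: What to Expect for Compound 3

The source may hold more compounds than are shown below. What is called first, only, known or untested is meant among the compounds shown, and "the series" means these compounds.

Compound 1 `O=C(CCC1=CCN(Cc2ccc(F)cc2)C1=O)NO` — 5990 nM
Compound 2 `O=C(CCC1=CCN(Cc2ccc(Cl)cc2)C1=O)NO` — 3330 nM

These two compounds share one core and differ only in the group on the aromatic ring. Among the measured compounds shown here, in a functional assay on ACHN cells (Homo sapiens) for inhibition, read by sulforhodamine B assay (a higher number here means a weaker inhibitor of growth, a lower number a stronger inhibitor of growth), compound 2 gives the lowest of the two numbers, yet the only measured step, a 1.8-fold lower number from compound 1 to compound 2 (0.25 log units; within the scatter), lies within the scatter, so the two compounds cannot be told apart on this evidence.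

Compound 3 `N#Cc1ccc(CN2CC=C(CCC(=O)NO)C2=O)cc1` takes the next step from compound 2: cyano in place of chloro on an aromatic carbon. For the measured compounds named here, no measured step covers a cyano group, and the one halogen swap that is known moved the number only within the scatter. Nothing in the data therefore points to a shift beyond the scatter in this assay in either direction.

Compound 3 is expected near 4000 nM, somewhere between 1500 nM and 11000 nM.

The expected step is a 1.2-fold higher number from compound 2 to compound 3 (0.08 log units; within the scatter), judged to stay within the scatter.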

Compound 3, concentration for 50% growth inhibition: > 10000 nM
Compound 3: only a limit was reported (the forecaster's own chance of this, stated with the estimate: 5%); at least 2.5-fold (0.39 log units) between middle value and limit.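

In this assay, the position para to a large group now shows that the choice of group there can matter, which the swap of one halogen for another could not show: cyano in place of chloro gives an at least 3.0-fold higher number from compound 2 to compound 3 (0.47 log units; beyond the scatter). Against fluoro the evidence is less firm, with an at least 1.6-fold higher number from compound 1 to compound 3 (0.22 log units; that floor lies within the scatter), so compound 3 cannot yet be separated from compound 1. The reading for compound 3 is a limit and not a number, so both steps give only a floor: the limit of > 10000 nM in this assay, at which 1 of the 3 values shown sits.

The compounds shown leave open how large the true step to compound 3 is. They also leave open whether the change follows from the cyano group specifically, or whether a methoxy group, an amine or a carboxylic acid at this position would give a similar result.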